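From vinyl to ethoxycarbonyl on one aromatic carbon

The compounds below may be only part of what the source reports. "The series", "measured", "known", "first", "only" and "open" are said of these compounds alone.

In a functional assay on A549 cells (Homo sapiens) for inhibition, read by CCK-8 assay, with a stated time of 48 h (a higher number here means a weaker inhibitor, a lower number a stronger inhibitor), compound 1 `COc1cc(-c2ccnc3cc(-c4ccc(F)cc4)nn23)cc(OC)c1OC` gives 3800 nM, compound 2 `COc1cc(-c2ccnc3cc(-c4ccc(Cl)cc4)nn23)cc(OC)c1OC` gives 3070 nM and compound 3 `C=Cc1ccc(-c2cc3nccc(-c4cc(OC)c(OC)c(OC)c4)n3n2)cc1` gives 1030 nM, the lowest number of the three. Chloro in place of fluoro stays within the scatter, with a 1.2-fold lower number from compound 1 to compound 2 (0.09 log units; within the scatter). Vinyl in place of either halogen goes beyond it, with a 3.7-fold lower number from compound 1 to compound 3 (0.57 log units; beyond the scatter) and a 3.0-fold lower number from compound 2 to compound 3 (0.47 log units; beyond the scatter). Compound 4 `CCOC(=O)c1ccc(-c2cc3nccc(-c4cc(OC)c(OC)c(OC)c4)n3n2)cc1` has ethoxycarbonyl in place of vinyl on an aromatic carbon, para to a large group: ethoxycarbonyl in place of vinyl on an aromatic carbon. Going by the values given here, no measured compound carries ethoxycarbonyl, so those two modest vinyl steps are the only guide to size. A modest rise is expected, namely a 2.1-fold higher number from compound 3 to compound 4 (0.33 log units; beyond the scatter). For compound 4 the estimated value is 2200 nM, with an expected range of 700 nM to 6500 nM.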

Compound 4, half-maximal inhibitory concentration: > 10000 nM
Compound 4 gave a limit, no number; the forecaster's own chance of this, stated with the estimate: 5%; middle value at least 4.5-fold (0.65 log units) from the limit.
By their numbers in this assay, from the lowest: compound 3; then compounds 2 and 1 (each within the scatter of the next). At a limit, above all of these: compound 4.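

In this assay compound 4 stands at a limit and not at a number: the limit of > 10000 nM in this assay, at which 1 of the 4 values shown sits. The earlier changes at this position either lowered the number or stayed within the scatter, so this is the first change shown to go the other way, with an at least 9.7-fold higher number from compound 3 to compound 4 (0.98 log units; beyond the scatter), an at least 3.2-fold higher number from compound 2 to compound 4 (0.51 log units; beyond the scatter) and an at least 2.6-fold higher number from compound 1 to compound 4 (0.42 log units; beyond the scatter). At this position, then, ethoxycarbonyl is not tolerated as well as vinyl or either halogen.

The compounds shown leave open how far beyond the limit compound 4 lies. They also leave open whether a carboxylic acid, an amide or a methyl ester on this carbon would behave like ethoxycarbonyl or like vinyl.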